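Trifluoromethyl for chloro on the urea-bearing ring

This account rests on a few compounds, and the source may have more. Where it says the series, first, only, none or still open, it means among the compounds named here.

Compound 1 `COc1cc(-c2nn(-c3cccc(NC(=O)Nc4ccc(Cl)c(Cl)c4)c3)cc2-c2ccncc2)ccc1Cl` is measured in a functional assay on TK-10 cells (Homo sapiens) for inhibition, read by sulforhodamine B assay, with a stated time of 48 h (a lower number here means a stronger inhibitor of growth, a higher number a weaker inhibitor of growth), at 1430 nM. Compound 2 `O=C(Nc1cccc(-n2cc(-c3ccncc3)c(-c3ccc(Cl)c(O)c3)n2)c1)Nc1ccc(Cl)c(Cl)c1` gives 1910 nM in this assay, and the step of a 1.3-fold higher number from compound 1 to compound 2 (0.13 log units; within the scatter) shows only hydrogen in place of methyl on an oxygen on an aromatic ring. Within the data shown here, compound 2 thus stands within the scatter of compound 1, the only other measured compound. Among the measured compounds shown here, compound 3 `O=C(Nc1cccc(-n2cc(-c3ccncc3)c(-c3ccc(Cl)c(O)c3)n2)c1)Nc1ccc(Cl)c(C(F)(F)F)c1` differs from compound 2 by trifluoromethyl in place of chloro on an aromatic carbon, a change no measured step covers. For the measured compounds named here, with no step bearing on it, compound 3 is expected near compound 2, around 1900 nM, between 800 nM and 4500 nM, meaning a 1.0-fold lower number from compound 2 to compound 3 (0.00 log units; within the scatter).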

Compound 3, concentration for 50% growth inhibition: 1500 nM
Estimate against measurement, compound 3: 1.3-fold (0.10 log units) above; measured number inside the range.
By their numbers in this assay, from the lowest: compounds 1, 3 and 2 (each within the scatter of the next).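

In this assay, replacing 3,4-dichlorophenyl with 4-chloro-3-(trifluoromethyl)phenyl gives a 1.3-fold lower number from compound 2 to compound 3 (0.10 log units; within the scatter). This position therefore takes a group of four heavy atoms in place of one, ortho to a chloro group, with no change beyond the scatter in growth inhibition. Nothing measured on these compounds bears on why the two groups read alike.

Still open, on these data alone, is whether an amine or a carboxylic acid at this position would read the same. The compounds shown also leave open whether trifluoromethyl here would read alike with the methyl on the oxygen of compound 1 kept.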